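Methylpiperazine in Place of the Bridged Diamine

This account rests on a few compounds, and the source may have more. Where it says the series, first, only, none or still open, it means among the compounds named here.

Compound 2 `CN(C[C@H]1Cc2c(cccc2N2C[C@@H]3C[C@H]2CN3)CN1)[C@H]1CCCc2cccnc21` stands second highest of the three measured compounds in an ADME assay on microsomes from liver (Mus musculus) for metabolic stability, read by LC-MS, with a stated time of 10 min (on this read-out higher numbers stand for a more stable compound and lower numbers for a less stable compound), giving 36.3%. Compound 1 `CN(C[C@H]1Cc2c(cccc2N2CCN(C3CC3)CC2)CN1)[C@H]1CCCc2cccnc21` gives 7%, while compound 3 `CC(C)N(C[C@H]1Cc2c(cccc2N2CCNCC2)CN1)[C@H]1CCCc2cccnc21` gives 91%. Compound 4 `CN1CCN(c2cccc3c2C[C@H](CN(C)[C@H]2CCCc4cccnc42)NC3)CC1` differs from compound 2 in one place: a group of 7 heavy atoms (5 carbon, 2 nitrogen; one six-membered non-aromatic ring with 2 hetero atoms) in place of a group of 7 heavy atoms (5 carbon, 2 nitrogen; 2 five-membered non-aromatic rings with 1 hetero atom each), on an aromatic carbon. Among the measured compounds shown here, the only measured step at that aromatic carbon is a number 29.3 percentage points higher from compound 1 to compound 2 (beyond the scatter), which moved toward the bridged pair of rings and brought a modest gain. Compound 3 differs from compound 4 in two places, so its value bears only loosely on this change. Moving back to a six-membered ring at this carbon suggests a fall beyond the scatter. Compound 4 is therefore expected to give 18%, within a range from 5% to 45%. The expected step is a number 18.3 percentage points lower from compound 2 to compound 4 (beyond the scatter).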

Compound 4, percent of the compound remaining: 17%
For compound 4 the middle estimate is 1 percentage points above the measured one; the measured number falls inside the stated range.
By their numbers in this assay, from the lowest: compounds 1 and 4 (each within the scatter of the next); then compound 2; then compound 3.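

Replacing the bridged pair of rings with 4-methylpiperazin-1-yl on this aromatic carbon gives a number 19.3 percentage points lower from compound 2 to compound 4 (beyond the scatter) in this assay. On the amine nitrogen of the piperazine ring, methyl in place of cyclopropyl gives a number 10 percentage points higher from compound 1 to compound 4 (within the scatter), so this change does not reproduce the gain seen with the bridged pair of rings in compound 2. No measurement here explains the difference between these groups.

Going by these compounds, it remains open where a morpholine or an ethyl group on the piperazine nitrogen would fall in this assay. Compound 3 differs from compound 4 in two places, so it cannot settle either question.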